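Aryl Swap on a Saturated Ring Carbon: Compound 3

The source may report more compounds than this note shows. Statements on the series, on what has been measured and on what is new or still open speak of the compounds shown alone.

Measured compounds:
- compound 1, `COc1cc(/C=C/C(=O)C2=C(/C=C/c3ccc(O)c(OC)c3)NC(=O)NC2c2ccc(C)cc2)ccc1O`: 23.9%
- compound 2, `COc1cc(/C=C/C(=O)C2=C(/C=C/c3ccc(O)c(OC)c3)NC(=O)NC2c2c(Cl)cccc2Cl)ccc1O`: 20%

In a functional assay, with a stated time of 20 min, tested at 10 uM (on this read-out lower numbers stand for a weaker effect and higher numbers for a stronger effect at the one concentration tested), compound 1 gives 23.9% and compound 2 gives 20%. Compound 2 stands lowest of the two numbers, but the step of a number 3.9 percentage points lower from compound 1 to compound 2 (within the scatter) lies within the scatter, so the two cannot be told apart. Compound 3 `COc1cc(/C=C/C(=O)C2=C(/C=C/c3ccc(O)c(OC)c3)NC(=O)NC2c2cccc([N+](=O)[O-])c2)ccc1O` differs from compound 2 by 3-nitrophenyl in place of 2,6-dichlorophenyl on a saturated ring carbon. Among the compounds with values here, the one measured step that bears on it is the earlier exchange of an aromatic group on the same saturated ring carbon, a number 3.9 percentage points lower from compound 1 to compound 2 (within the scatter), which stayed within the scatter. With that single step as guide, the expected step of a number 2 percentage points higher from compound 2 to compound 3 (within the scatter) is none beyond the scatter. Compound 3 is therefore estimated at 22% in this assay, with a range from 12% to 32%.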

Compound 3, a percentage reported as activity, at one concentration (the size of the read-out at that concentration, not a potency): 19.9%
Compound 3: middle estimate off by 2.1 percentage points, on the high side; the range from low to high includes it.
By their numbers in this assay, from the lowest: compounds 3, 2 and 1 (each within the scatter of the next).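

Exchanging 2,6-dichlorophenyl for 3-nitrophenyl on this saturated ring carbon gives a number 0.1 percentage points lower from compound 2 to compound 3 (within the scatter) in this assay, and exchanging 4-methylphenyl for it gives a number 4 percentage points lower from compound 1 to compound 3 (within the scatter). Within the data shown here, the position has now taken three differently substituted phenyl groups, carrying methyl, chlorine or nitro, and compound 1, compound 2 and compound 3 cannot be told apart, whereas the earlier pair offered only a single exchange. No further measurement bears on this result, so it offers no explanation.

As far as these compounds go, all three compounds keep a substituted phenyl ring at this carbon, so it remains open whether an amine or a carboxylic acid on that ring, or a cyclohexyl ring in its place, would give a different number. The shown compounds also leave open what changes at the 2-(4-hydroxy-3-methoxyphenyl)ethenyl group would do.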